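This account rests on a few compounds, and the source may have more. Where it says the series, first, only, none or still open, it means among the compounds named here.

In a functional assay on L1210 cells (Mus musculus) for inhibition (a higher number here means a weaker inhibitor, a lower number a stronger inhibitor), compound 1 (`C=C1[C@H](n2cnc3c(Cl)nc(N)nc32)O[C@H](CO)[C@H]1O`) gives 10000 nM, and compound 2 (`C=C1[C@H](n2cnc3c(O)nc(N)nc32)O[C@H](CO)[C@H]1O`) gives 8500 nM. The two stand level: the measured step is a 1.2-fold lower number from compound 1 to compound 2 (0.07 log units; within the scatter), so the pair shows no order. Compound 3 (`C=C1[C@H](n2cnc3c(N(C)C)nc(N)nc32)O[C@H](CO)[C@H]1O`) is the next step from compound 2, with dimethylamino in place of hydroxy on an aromatic carbon. For the measured compounds named here, only one measured step bears on this change, the one between compound 1 and compound 2, which swaps hydroxy for chloro on that same aromatic carbon and stays within the scatter. Dimethylamino itself has not been measured in this series, so that single small step is weak guidance. No step beyond the scatter is expected in this assay. The estimated change is a 1.1-fold higher number from compound 2 to compound 3 (0.02 log units; within the scatter). For compound 3 the expected value is 9000 nM, with an estimated range of 3000 nM to 27000 nM.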

Compound 3, half-maximal inhibitory concentration: 454000 nM
Compound 3: the middle estimate sits 50-fold (1.70 log units) below what was measured; the measured number lies above the stated range.
By their numbers in this assay, from the lowest: compounds 2 and 1 (each within the scatter of the next); then compound 3.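

Dimethylamino on this aromatic carbon gives, in this assay, a 53-fold higher number from compound 2 to compound 3 (1.73 log units; beyond the scatter) and a 45-fold higher number from compound 1 to compound 3 (1.66 log units; beyond the scatter), so the position is not indifferent to its substituent, as the chloro and hydroxy pair alone suggested. That pair stays level, with a 1.2-fold lower number from compound 1 to compound 2 (0.07 log units; within the scatter), which means that the tolerance seen for those two groups does not extend to dimethylamino, the group that brings 3 heavy atoms where hydroxy has 1. Nothing available explains why this change carries such a large step.

From the compounds shown here alone, whether a plain amine or a methylamino group on this carbon stays level with compound 1 and compound 2 or falls toward compound 3 remains open, as does the behaviour of a methoxy group. The compounds also leave open whether a change at the amino group on the same ring would matter as much.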